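Cytotoxicity of Four Sulfonamides in Liver Cells

The source may hold more compounds than are shown below. What is called first, only, known or untested is meant among the compounds shown, and "the series" means these compounds.

Measured so far:
compound 1 `O=S(=O)(Cc1ccccc1)N1CCC2(CC1)OOC1(CCCC1)OO2`: > 100 ug/mL
compound 2 `O=S(=O)(Cc1ccccc1)N1CCC2(CC1)OOC1(CCCCC1)OO2`: > 100 ug/mL
compound 3 `Cc1ccc(S(=O)(=O)N2CCC3(CC2)OOC2(CCCC2)OO3)cc1`: > 100 ug/mL

In a functional assay on Huh-7 cells (Homo sapiens) for cytotoxicity, read by MTT assay, with a stated time of 72 h (a lower number here means that less compound is tolerated, a higher number that more compound is tolerated), compound 1 gives > 100 ug/mL, which is a limit of the assay and not a number. In this assay compound 2 gives > 100 ug/mL, again a limit. In this assay compound 3 gives > 100 ug/mL, also a limit. Compound 1 and compound 3 differ in one place, (4-methylphenyl in place of benzyl on a sulfonyl sulfur), and the step that the two limits leave unreadable from compound 1 to compound 3 cannot be read because both of its ends are limits. The difference between the core of compound 1 and the core of compound 2 is not broken down here; compound 2 stands only at a limit, as do the two other values shown.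

All three measured values sit at the limit of > 100 ug/mL in this assay, at which 3 of the 3 values shown sit.

Compound 4 `Cc1ccc(S(=O)(=O)N2CCC3(CC2)OOC2(CCCCC2)OO3)cc1` is not yet measured. It differs from compound 2 by 4-methylphenyl in place of benzyl on a sulfonyl sulfur, the same change, at the same kind of place, as from compound 1 to compound 3. From compound 2 to compound 4 a step that the limit leaves unreadable from compound 2 to compound 4 is expected, because the earlier step of this change was unreadable and all three measured values sit at the limit of > 100 ug/mL in this assay, at which 3 of the 3 values shown sit. For compound 4 in this assay the estimate is 150 ug/mL. For compound 4 the expected range runs from 70 ug/mL to 400 ug/mL, with the result most likely to be reported as a limit once more.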

Compound 4, half-maximal cytotoxic concentration: > 100 ug/mL
Compound 4 ended at the assay's limit; the forecaster's own chance of this, stated with the estimate: 85%; the middle value lies beyond the limit too.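

In this assay compound 4 gives > 100 ug/mL, which is a limit of the assay and not a number. Compound 2 stands at a limit as well, so no step can be read between compound 2 and compound 4. The compounds shown leave open the concentration at which any of them harms the cells, and whether 4-methylphenyl in place of benzyl changes it at all: the limit of > 100 ug/mL in this assay, at which 4 of the 4 values shown sit.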